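The source may hold more compounds than are shown below. What is called first, only, known or untested is meant among the compounds shown, and "the series" means these compounds.

In a functional assay on HeLa cells (Homo sapiens) for inhibition, read by sulforhodamine B assay, with a stated time of 48 h (on this read-out higher numbers stand for weaker inhibition of growth and lower numbers for stronger inhibition of growth), three compounds have been measured. Compound 1 `COc1cc(/C=C/C(=O)N2CCC=CS2(=O)=O)cc(OC)c1OC` gives 14300 nM in this assay, and compound 2 `O=C(/C=C/c1cccs1)N1CCC=CS1(=O)=O` gives 18800 nM. Going by the values given here, compound 3 `COc1cc(/C=C/C(=O)N2CCC=CS2(=O)=O)cc(OC)c1` returns only a limit of the assay, < 100 nM, and so has no number of its own; it sits at the limit of < 100 nM in this assay, at which 1 of the 3 values shown sits, the one value of the three that is a limit. Among the compounds with values here, the only step between neighbours, an at least 140-fold lower number from compound 1 to compound 3 (2.15 log units; beyond the scatter), is large, though its true size is open because compound 3 is at a limit.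

Compound 4 `COc1cccc(/C=C/C(=O)N2CCC=CS2(=O)=O)c1` is not yet measured. It differs from compound 3 by hydrogen in place of methoxy on an aromatic carbon. The same kind of change, a methoxy replaced by hydrogen, is the one made in an at least 140-fold lower number from compound 1 to compound 3 (2.15 log units; beyond the scatter), but that step started from a measured number and ended at a limit, so it cannot say how far compound 3 really lies from the limit nor whether a second such removal continues in the same direction. Compound 4 is therefore expected to give about 300 nM, within a wide band from 30 nM to 3000 nM. The expected step, an at least 3.0-fold higher number from compound 3 to compound 4 (0.47 log units; beyond the scatter), is a rise in the number, but it rests on an uncertain starting point and may also come back as a limit.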

Compound 4, concentration for 50% growth inhibition: 23700 nM
Beside the measured number, compound 4's estimate is 79-fold (1.90 log units) below it; measured number outside the range, above it.
By their numbers in this assay, from the lowest: compounds 1, 2 and 4 (each within the scatter of the next). At a limit, below all of these: compound 3.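

In this assay the same change, hydrogen in place of methoxy on an aromatic carbon, now runs the other way: the earlier step was an at least 140-fold lower number from compound 1 to compound 3 (2.15 log units; beyond the scatter) and this one is an at least 230-fold higher number from compound 3 to compound 4 (2.37 log units; beyond the scatter). Removing a methoxy therefore has no single direction across these compounds, and its outcome depends on which methoxy leaves and what remains on the ring. The methoxy lost here, meta to a large group and meta to a methoxy group, is one that compound 3 cannot lose without giving up its low number.

As far as these compounds go, compound 3 stands at a limit of the assay, and the true size of both steps stays open with it: the limit of < 100 nM in this assay, at which 1 of the 4 values shown sits. From the compounds shown here alone, whether an ethoxy, a hydroxyl or a chlorine at this place would hold the low number also remains open.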